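Pyrrole in Place of Chlorophenyl on the Hydrazone Carbon

The source may hold more compounds than are shown below. What is called first, only, known or untested is meant among the compounds shown, and "the series" means these compounds.

Within the data shown here, compound 3 `CC1=CC[C@H](C(C)(C)NC(=S)N/N=C/c2ccc(Cl)cc2)CC1` holds the only measured number: in a functional assay on K562 cells (Homo sapiens) for inhibition, read by sulforhodamine B assay, with a stated time of 48 h (on this read-out higher numbers stand for weaker inhibition of growth and lower numbers for stronger inhibition of growth), compound 3 gives 300 nM. Compound 1 `CC1=CC[C@H](C(C)(C)NC(=S)NN)CC1` sits at the limit, giving > 100000 nM in this assay. Compound 2 `CC1=CC[C@H](C(C)(C)NC(=S)N/N=C/c2ccc(O)cc2)CC1` likewise reaches only the limit, giving > 100000 nM in this assay, so two of the three values stop at the limit of > 100000 nM in this assay, at which 2 of the 3 values shown sit. Among the measured compounds shown here, the one measured step, an at least 330-fold lower number from compound 2 to compound 3 (2.52 log units; beyond the scatter), is large. Compound 4 `CC1=CC[C@H](C(C)(C)NC(=S)N/N=C/c2ccc[nH]2)CC1` differs from compound 3 by 1H-pyrrol-2-yl in place of 4-chlorophenyl on a carbon with a double bond to nitrogen; the entering group carries a hydrogen-bond donor, as the hydroxy of compound 2 does. A step toward weaker inhibition of growth, a 67-fold higher number from compound 3 to compound 4 (1.82 log units; beyond the scatter), is therefore expected. Compound 4 is estimated at 20000 nM, with a range from 3000 nM to 150000 nM.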

Compound 4, concentration for 50% growth inhibition: 23400 nM
Compound 4: middle estimate off by 1.2-fold (0.07 log units), on the low side; low and high end bracket the measured number.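

In this assay, the change on the carbon with a double bond to nitrogen gives a 78-fold higher number from compound 3 to compound 4 (1.89 log units; beyond the scatter), so 1H-pyrrol-2-yl gives a measured number but falls well short of 4-chlorophenyl. The other two steps read an at least 4.2-fold lower number from compound 2 to compound 4 (0.63 log units; beyond the scatter) and an at least 4.2-fold lower number from compound 1 to compound 4 (0.63 log units; beyond the scatter), which places compound 4 on the stronger side of both. Compound 1 and compound 2 each give a limit and not a number, so those two steps have no fixed size: the limit of > 100000 nM in this assay, at which 2 of the 4 values shown sit.

The compounds shown leave open how 4-bromophenyl, 4-methoxyphenyl or furan-2-yl would read at this place.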